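The compounds below may be only part of what the source reports. "The series", "measured", "known", "first", "only" and "open" are said of these compounds alone.

For the measured compounds named here, compound 2 `COc1cccc2c1c(NS(=O)(=O)c1ccc(Cl)s1)nn2Cc1cccc(CNC(=O)C2CCO2)c1` is one of two compounds measured so far in a functional assay on CHO cells for antagonist activity at C-C chemokine receptor type 4 (Homo sapiens), read by GTPgammaS binding; on this read-out lower numbers stand for stronger inhibition and higher numbers for weaker inhibition. In this assay compound 2 gives 31.6 nM, the higher of the two numbers. The other compound, compound 1 `CC(=O)NCc1cccc(Cn2nc(NS(=O)(=O)c3ccc(Cl)s3)c3c(C(C)O)cccc32)c1`, gives 20 nM in this assay, and the two values lie within the scatter of each other. Compound 1 and compound 2 differ in more than one place. Nothing further can be read from that pair.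

Compound 3 `COc1cccc2c1c(NS(=O)(=O)c1ccc(Cl)s1)nn2Cc1cccc(CNC(=O)[C@@H]2CCCCN2)c1` has not yet been measured. It is derived from compound 2 by a single change: piperidin-2-yl in place of oxetan-2-yl on a carbonyl carbon. Going by the values given here, no step between two measured compounds matches this change, so there is no directly comparable step to lean on. With that in mind, compound 3 is expected to stay in the range already seen, with a step of a 1.3-fold lower number from compound 2 to compound 3 (0.10 log units; within the scatter) in this assay, which is to say no movement beyond the usual scatter in either direction. On that basis compound 3 is estimated to give about 25 nM in this assay, with a plausible range running from 8 nM to 80 nM.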

Compound 3, half-maximal inhibitory concentration: 15.9 nM
For compound 3 the middle estimate is 1.6-fold (0.20 log units) above the measured one; the measured number falls inside the stated range.
By their numbers in this assay, from the lowest: compounds 3, 1 and 2 (each within the scatter of the next).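

In this assay, putting piperidin-2-yl in place of oxetan-2-yl on a carbonyl carbon gives a 2.0-fold lower number from compound 2 to compound 3 (0.30 log units; within the scatter). For the compounds shown here, this is the first comparison here between two compounds that differ in only one place, and it shows that this position can carry quite different groups without a change beyond the scatter: a four-membered ring holding one oxygen and a six-membered ring holding one nitrogen, which also brings a hydrogen-bond donor and a defined stereocentre. No measurement of any property of these two groups is at hand to account for this result.

The compounds shown leave open whether the ring nitrogen matters at all, a question that a cyclohexyl ring on the same carbonyl carbon would address, and whether the mirror-image form of piperidin-2-yl would stay in the same range. As far as these compounds go, it also remains open how far this position stretches, for instance to an open-chain group such as aminomethyl or to a carboxylic acid, since one step within the scatter sets no limit on what the position will accept.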